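A Chloro Added to the Shared Core: Expected Solubility

The source may report more compounds than this note shows. Statements on the series, on what has been measured and on what is new or still open speak of the compounds shown alone.

Compound 1 `O=C(Nc1ccc(C(F)(F)F)cc1)c1cc(Cl)ccc1O` was tested in a physicochemical assay for solubility; on this read-out lower numbers stand for lower solubility and higher numbers for higher solubility. In this assay compound 1 gives < 1 ug/mL, which is a limit of the assay and not a number. Compound 2 `O=C(Nc1ccc(C(F)(F)F)cc1Cl)c1cc(Cl)ccc1O` carries the change chloro in place of hydrogen on an aromatic carbon on the core of compound 1. In this assay compound 2 gives < 1 ug/mL, again a limit rather than a number. The step that the two limits leave unreadable from compound 1 to compound 2 therefore cannot be sized, since both ends sit at the limit of < 1 ug/mL in this assay, at which 2 of the 3 values shown sit.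

Compound 3 `COc1cccc(NC(=O)c2cc(Cl)ccc2O)c1` is built on a different core; the difference between the two cores is not broken down here. In this assay, going by the values given here, compound 3 gives 2.3 ug/mL, the only value among the three that is a number rather than a limit.

Compound 4 `COc1ccc(Cl)c(NC(=O)c2cc(Cl)ccc2O)c1` has not yet been measured. It differs from compound 3 by chloro in place of hydrogen on an aromatic carbon, the same kind of change as that from compound 1 to compound 2, though the surroundings differ: in compound 2 the chloro sits meta to a trifluoromethyl group, whereas in compound 4 it sits para to a methoxy group. The measured pair gives no readable size for this change. The expected step is a 2.3-fold lower number from compound 3 to compound 4 (0.36 log units; beyond the scatter), resting only on compound 3 standing at 2.3 ug/mL. Compound 4 is estimated at 1 ug/mL, between 0.3 ug/mL and 3 ug/mL, with a real chance of only a limit being reported.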

Compound 4, solubility: < 1 ug/mL
Compound 4 gave a limit, no number; the forecaster's own chance of this, stated with the estimate: 45%; the middle value lies on the limit itself.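

In this assay the chloro in place of hydrogen, here ortho to a large group and para to a methoxy group, gives an at least 2.3-fold lower number from compound 3 to compound 4 (0.36 log units; beyond the scatter), so on the core of compound 3 this change does lower the read-out by more than the usual scatter. Compound 4 gives < 1 ug/mL, which is a limit of the assay and not a number, so this step has a smallest size but no full size. The same change on the core of compound 1 cannot be read, so the series offers one readable case and no second size to set against it, and nothing here shows that the step carries over from one core to the other, with most values resting at the same limit: the limit of < 1 ug/mL in this assay, at which 3 of the 4 values shown sit.

What the compounds shown leave open is whether an amine or a carboxylic acid, put in place of the methoxy group or the trifluoromethyl group, would give a value that is a number rather than a limit. Also open is whether a chloro at another place on that aromatic ring would give a step of similar size, as only the place para to a methoxy group is shown.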